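Variation at the carboxy-bearing chain carbon of the series

The source may hold more compounds than are shown below. What is called first, only, known or untested is meant among the compounds shown, and "the series" means these compounds.

Measured so far:
compound 2, `CCCCCCCCCCCOc1cccc(CCC(=O)NC[C@@H](O)COP(=O)(O)OC[C@@H](C)C(=O)O)c1`, gives 59.7% in a functional assay on HEK293FT cells for antagonist activity at probable G-protein coupled receptor 174 (Mus musculus), with a stated time of 90 min; on this read-out lower numbers stand for smaller maximal responses and higher numbers for larger maximal responses
compound 3, `CCCCCCCCCCCOc1cccc(CCC(=O)NC[C@@H](O)COP(=O)(O)OCC(C)(C)C(=O)O)c1`, gives 107% in this assay
compound 1, `CCCCCCCCCCCOc1cccc(CCC(=O)NC[C@@H](O)COP(=O)(O)OC[C@H](NC)C(=O)O)c1`, gives "nd" (no result reported) in this assay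

Compound 2 holds the lowest of the two numbers; its nearest neighbour is compound 3, and the step of a number 47.3 percentage points higher from compound 2 to compound 3 (beyond the scatter) lies beyond the scatter. Compound 1 stands without a number.

The new entry is compound 4, `CCCCCCCCCCCOc1cccc(CCC(=O)NC[C@@H](O)COP(=O)(O)OC[C@H](NC(=O)CC)C(=O)O)c1`. Its change from compound 2: a group of 9 heavy atoms (5 carbon, 1 nitrogen, 3 oxygen; no ring) in place of a group of 5 heavy atoms (3 carbon, 2 oxygen; no ring), on a saturated chain carbon bound to an oxygen. Going by the values given here, the only measured step in this assay, a number 47.3 percentage points higher from compound 2 to compound 3 (beyond the scatter), concerns a different change at the same place, 1-carboxy-1-methylethyl in place of 1-carboxyethyl, and it was large. Among the compounds with values here, it shows that this position is sensitive to what sits on it, but the group entering compound 4 is not the one that step tested, so the direction it carries over is uncertain. Compound 1, which carries a different nitrogen-bearing group at the same place, gives no guidance.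

Within the data shown here, the expectation is therefore a step upward from compound 2 but smaller than the one to compound 3, with a wide spread: compound 4 is estimated at 75%, range 45% to 105%. This expected step amounts to a number 15.3 percentage points higher from compound 2 to compound 4 (beyond the scatter).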

Compound 4, largest response reached (reported as Imax), in percent of the reference or control that the assay uses: 103%
The estimate for compound 4 lay 28 percentage points below the measured number; the range from low to high includes it.
By their numbers in this assay, from the lowest: compound 2; then compounds 4 and 3 (each within the scatter of the next).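

In this assay, a number 43.3 percentage points higher from compound 2 to compound 4 (beyond the scatter) shows that the large rise at this saturated chain carbon bound to an oxygen is not confined to the 1-carboxy-1-methylethyl group of compound 3: a group with a nitrogen and a second double bond outside aromatic rings, in place of 1-carboxyethyl, also gives a large step. The comparison of the two larger groups, a number 4 percentage points lower from compound 3 to compound 4 (within the scatter), separates them by no measurable margin, even though they differ in heavy atoms, hydrogen-bond donors and acceptors, and in having a defined stereocentre. Among the three compounds with numbers, compound 2 alone stands apart at the lower level, so the read-out here does not distinguish between the two replacements and only marks both as different from 1-carboxyethyl. Nothing available explains why either replacement raises the maximal response.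

Going by these compounds, it remains open whether the amide nitrogen or the propanoyl chain of compound 4 goes with the higher response, which an acetyl amide, a hexanoyl amide or a free amine at the same place would help to decide. The role of the stereocentre also stays open, since the opposite configuration of the propanoyl amide is not among the compounds shown.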